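This account rests on a few compounds, and the source may have more. Where it says the series, first, only, none or still open, it means among the compounds named here.

Measured compounds:
- compound 1 `COc1cc2cc(Oc3ccc(NC(=O)Nc4cccc(C(F)(F)F)c4)cc3)c(C)nc2cc1OC`: 7710 nM
- compound 2 `COc1cc2cc(Oc3ccc(NC(=O)Nc4ccc(Cl)c(C(F)(F)F)c4)cc3)c(C)nc2cc1OC`: 4000 nM

Within the data shown here, both compounds have been tested in a functional assay on ACHN cells (Homo sapiens) for inhibition, read by sulforhodamine B assay, with a stated time of 48 h; on this read-out lower numbers stand for stronger inhibition of growth and higher numbers for weaker inhibition of growth. In this assay compound 1 gives 7710 nM, and compound 2 gives 4000 nM. Compound 2 has the lowest of the two numbers shown, but the only measured step, a 1.9-fold lower number from compound 1 to compound 2 (0.28 log units; within the scatter), lies within the scatter, so the two compounds cannot be told apart on this read-out.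

Compound 3 `COc1cc2cc(Oc3ccc(NC(=O)Nc4ccc(Cl)c(Cl)c4)cc3)c(C)nc2cc1OC` has not yet been measured. It differs from compound 2 in one place: chloro in place of trifluoromethyl on an aromatic carbon. Among the measured compounds shown here, the one measured step bears on it only loosely: from compound 1 to compound 2 a chloro group was added where there had been hydrogen, and that change stayed within the scatter, a 1.9-fold lower number from compound 1 to compound 2 (0.28 log units; within the scatter). For the measured compounds named here, no measured step exchanges a trifluoromethyl for a chloro, so there is no direct precedent. Going by the values given here, because the only measured change at this ring gave a 1.9-fold lower number from compound 1 to compound 2 (0.28 log units; within the scatter), the expected step for compound 3 is a 1.1-fold higher number from compound 2 to compound 3 (0.05 log units; within the scatter), meaning no change beyond the scatter. On that basis compound 3 is estimated at 4500 nM, with a range from 1500 nM to 13000 nM.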

Compound 3, concentration for total growth inhibition: 12100 nM
The estimate for compound 3 lay 2.7-fold (0.43 log units) below the measured number, within the range that was stated.
By their numbers in this assay, from the lowest: compounds 2, 1 and 3 (each within the scatter of the next, the first and the last beyond it).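

In this assay, among these compounds, chloro in place of trifluoromethyl on an aromatic carbon, ortho to a chloro group, gives a 3.0-fold higher number from compound 2 to compound 3 (0.48 log units; beyond the scatter) and is the first step here to pass beyond the scatter. This modest step shows that the group at this position can change the read-out, which the earlier hydrogen-to-chloro step could not show. The wider change of 3,4-dichlorophenyl in place of 3-(trifluoromethyl)phenyl gives a 1.6-fold higher number from compound 1 to compound 3 (0.20 log units; within the scatter) and stays within the scatter, so compound 1 and compound 3 cannot be told apart, and the effect of this position is visible only when the chloro group of compound 2 is kept in place. Nothing given here explains why trifluoromethyl and chloro differ at this position.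

The compounds shown leave open how other groups at this position would read, such as a methoxy group, a nitrile, an amine or a longer alkyl chain. They also leave open whether a step of this size would recur on a ring carrying something other than chloro as its second group.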